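Trimming One Trifluoromethyl Group From Compound 3

A few compounds are considered here, and "the series" means these few. Any claim that something is new, unique, unknown or untested is made for them only; others in the source may bear on it.

Measured compounds:
compound 1 `O=C(Nc1cccc(-n2cc(-c3ccncc3)c(-c3cc(O)cc(Cl)c3)n2)c1)Nc1ccc(Cl)c(C(F)(F)F)c1` gives -52%
compound 2 `O=C(Nc1cccc(-n2cc(-c3ccncc3)c(-c3cc(O)cc(Cl)c3)n2)c1)Nc1ccc(Cl)c(Cl)c1` gives -38%
compound 3 `COc1cc(Cl)cc(-c2nn(-c3cccc(NC(=O)Nc4cc(C(F)(F)F)cc(C(F)(F)F)c4)c3)cc2-c2ccncc2)c1` gives -62%

In a functional assay on OVCAR-8 cells (Homo sapiens) for inhibition, read by sulforhodamine B assay, with a stated time of 48 h, tested at 100 uM (on this read-out higher numbers stand for a weaker effect at the one concentration tested and lower numbers for a stronger effect), compound 3 stands at the lowest of the three numbers: its gap to compound 1 is within the scatter, while its gap to compound 2 is beyond it. Compound 4 `COc1cc(Cl)cc(-c2nn(-c3cccc(NC(=O)Nc4cccc(C(F)(F)F)c4)c3)cc2-c2ccncc2)c1` differs from compound 3 by hydrogen in place of trifluoromethyl on an aromatic carbon. Going by the values given here, only one measured step bears on such a change: a number 14 percentage points higher from compound 1 to compound 2 (beyond the scatter), which also replaced a trifluoromethyl group on the same urea-bearing ring and gave a modest rise in the number. A step of about that size, in the same direction, is therefore expected here, a number 12 percentage points higher from compound 3 to compound 4 (beyond the scatter). Compound 4 is accordingly estimated at -50%, with a range from -70% to -25%.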

Compound 4, a percentage reported as activity, at one concentration (the size of the read-out at that concentration, not a potency): -43%
Compound 4: middle estimate off by 7 percentage points, on the low side; low and high end bracket the measured number.
By their numbers in this assay, from the lowest: compounds 3, 1, 4 and 2 (each within the scatter of the next, the first and the last beyond it).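

Replacing one trifluoromethyl group with hydrogen gives a number 19 percentage points higher from compound 3 to compound 4 (beyond the scatter) with a second trifluoromethyl group still on the ring. On this read-out a higher number means a weaker effect, so the effect at this carbon depends on the group that leaves, not only on the one that stays. Nothing measured here explains the step. Going by these compounds, what remains open is whether a methyl group, an amine or a carboxylic acid on this carbon would give a number nearer to that of compound 3 or compound 4.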